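Compound 2 to Compound 4: One Chain Carbon Changes

The source may hold more compounds than are shown below. What is called first, only, known or untested is meant among the compounds shown, and "the series" means these compounds.

Of the compounds shown here, three have so far been measured in an ADME assay on 184B5 cells (Homo sapiens) for cytotoxicity, read by MTT assay, with a stated time of 72 h; a higher number here means a weaker inhibitor of growth, a lower number a stronger inhibitor of growth. Compound 1 `CC(C)COC(=O)Nc1ccc([Se][Se]c2ccc(NC(=O)OCC(C)C)cc2)cc1` gives 5500 nM, compound 2 `CCCOC(=O)Nc1ccc([Se]C#N)cc1` gives 3700 nM, and compound 3 `CCCCCCOC(=O)Nc1ccc([Se][Se]c2ccc(NC(=O)OCCCCCC)cc2)cc1` gives 4600 nM. Compound 2 stands with the lowest number of the three, but its gaps to compound 3 and to compound 1 both lie within the usual scatter of repeated measurements, so the three cannot be placed in any order on these numbers.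

Compound 4 `C=CCOC(=O)Nc1ccc([Se]C#N)cc1` has not yet been measured in this assay. Its difference from compound 2 is vinyl in place of ethyl on a saturated chain carbon bound to an oxygen next to a carbonyl group. Going by the values given here, no pair of measured compounds differing in one place is available to show what such a change does here, and the three measured compounds are themselves spread over a narrow span. On that basis no step beyond the scatter is expected in either direction. Compound 4 is therefore expected to give about 3700 nM, with a range from 1800 nM to 7500 nM. The estimated step is no change at the digits printed from compound 2 to compound 4 (within the scatter), no change beyond the scatter.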

Compound 4, concentration for 50% growth inhibition: 5000 nM
Beside the measured number, compound 4's estimate is 1.4-fold (0.13 log units) below it, and the stated range covers the measured number.
By their numbers in this assay, from the lowest: compounds 2, 3, 4 and 1 (each within the scatter of the next).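

In this assay, going by these compounds alone, vinyl in place of ethyl on a saturated chain carbon bound to an oxygen next to a carbonyl group gives a 1.4-fold higher number from compound 2 to compound 4 (0.13 log units; within the scatter) and is the first step here that isolates a single difference. Compound 2 and compound 4 therefore cannot be told apart in this assay: at this place, with two heavy atoms leaving and two entering, the double bond that vinyl brings produces no step beyond the scatter. Nothing shown offers an explanation for this result.

This single pair leaves open what an amine, a carboxylic acid or a longer chain would do at the same chain carbon, since only vinyl and ethyl have been compared there. Compound 1 and compound 3 differ from compound 2 and compound 4 in more than one place, so they cannot show whether the same swap would also leave the number within the scatter on another part of the structure.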